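A few compounds are considered here, and "the series" means these few. Any claim that something is new, unique, unknown or untested is made for them only; others in the source may bear on it.

Of the compounds shown here, three built on one shared core have been measured in an assay for inhibition of serine/threonine-protein kinase PAK 4 (Homo sapiens), read by FRET and Z'-LYTE, with a stated time of 60 min, tested at 5 uM, in the presence of a further agent that is not named here (on this read-out higher numbers stand for a stronger effect at the one concentration tested and lower numbers for a weaker effect), and a fourth is now to be tested. Compound 1 `C[C@@H]1CN(C(=O)c2nc(Nc3cc(C4CC4)[nH]n3)c3cc(Cl)ccc3n2)CCN1C(=O)OC(C)(C)C` gives 22.7%. Compound 2 `C[C@@H]1CN(C(=O)c2nc(Nc3cc(C4CC4)[nH]n3)c3cc(Cl)ccc3n2)CCN1C(=O)OCc1ccccc1` gives 74%, and compound 3 `CC(C)OC(=O)N1CCN(C(=O)c2nc(Nc3cc(C4CC4)[nH]n3)c3cc(Cl)ccc3n2)C[C@H]1C` gives 75.8%. Compound 3 thus holds the highest of the three numbers, though its gap to compound 2 is within the scatter, while compound 1 lies far lower than both.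

Compound 4 `CC(C)COC(=O)N1CCN(C(=O)c2nc(Nc3cc(C4CC4)[nH]n3)c3cc(Cl)ccc3n2)C[C@H]1C` differs from compound 3 in one place: isobutyl in place of isopropyl on an oxygen next to a carbonyl group. Two steps speak to this kind of exchange on the oxygen next to the carbonyl group. The step of a number 51.3 percentage points higher from compound 1 to compound 2 (beyond the scatter) and the step of a number 53.1 percentage points higher from compound 1 to compound 3 (beyond the scatter) both show a large rise on leaving tert-butyl, whereas the step of a number 1.8 percentage points higher from compound 2 to compound 3 (within the scatter), an exchange of two groups that are not tert-butyl, stays within the scatter. An isobutyl group, like isopropyl and benzyl, is not tert-butyl, so compound 4 is expected to stay close to compound 3, with any step in this assay no larger than the scatter. The expected step is a number 3.8 percentage points lower from compound 3 to compound 4 (within the scatter). Compound 4 is therefore estimated at 72%, within a range from 52% to 88%.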

Compound 4, a percentage reported as inhibition, at one concentration (the size of the read-out at that concentration, not a potency): 30.7%
The estimate for compound 4 lay 41.3 percentage points above the measured number; the measured number lies below the stated range.
By their numbers in this assay, from the lowest: compounds 1 and 4 (each within the scatter of the next); then compounds 2 and 3 (each within the scatter of the next).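

In this assay, going by these compounds alone, the earlier compounds suggested that only tert-butyl on this oxygen stood apart, but this result shows that a small change away from tert-butyl can also matter: isobutyl, with 4 carbon atoms against 3 in isopropyl, gives a number 45.1 percentage points lower from compound 3 to compound 4 (beyond the scatter). The exchange of benzyl for isobutyl points the same way, with a number 43.3 percentage points lower from compound 2 to compound 4 (beyond the scatter), whereas a number 8 percentage points higher from compound 1 to compound 4 (within the scatter) leaves isobutyl and tert-butyl indistinguishable, so the four groups now fall into two sets, isobutyl with tert-butyl and isopropyl with benzyl. No measurement available here offers a reason for this split.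

From the compounds shown here alone, it remains open whether an ethyl, a cyclopropylmethyl or a longer chain such as n-butyl on this oxygen would sit with compound 1 and compound 4 or with compound 2 and compound 3. Going by these compounds, these readings also come from a single concentration, so how far the two sets differ in potency remains open too.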